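A few compounds are considered here, and "the series" means these few. Any claim that something is new, unique, unknown or untested is made for them only; others in the source may bear on it.

Measured so far:

compound 1 `COc1cccc(N2C(=O)COc3ccc(-c4cnc(Cl)c(NS(=O)(=O)c5ccc(F)cc5)c4)cc32)c1` — in a functional assay on HepG2 cells (Homo sapiens) for antiproliferative activity, read by MTT assay, with a stated time of 72 h (a lower number here means a stronger inhibitor, a higher number a weaker inhibitor), compound 1 gives > 40000 nM, which is a limit of the assay rather than a number.

compound 2 `O=C1COc2ccc(-c3ccc(O)cc3)cc2N1` — in this assay compound 2 gives 38200 nM.

On these data alone, compound 1 therefore stands at the edge of what this assay can report: it sits at the limit of > 40000 nM in this assay, at which 1 of the 2 values shown sits, so its true value is unknown beyond the fact that it is weak. Compound 2, a much smaller molecule sharing only the core, gives a plain number that is itself very weak. Among the measured compounds shown here, no step between two measured compounds is available, so nothing in these data shows how any single structural change moves the read-out.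

The compound not yet measured is compound 3 `COc1ccc(N2C(=O)COc3ccc(-c4cnc(Cl)c(NS(=O)(=O)c5ccc(F)cc5)c4)cc32)cc1`. It differs from compound 1 by 4-methoxyphenyl in place of 3-methoxyphenyl on an amide-type nitrogen in a ring: the same atoms, joined differently, with the methoxy group of the aryl ring on the ring amide nitrogen moved to another position on that ring. With compound 1 already at the limit, the step from compound 1 to compound 3 is expected to be a number no higher from compound 1 to compound 3 (the limit leaves the size open), that is nothing beyond the usual scatter, and compound 3 is estimated to give 40000 nM, within the range 15000 nM to 100000 nM, with a considerable chance that this assay again reports only a limit.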

Compound 3, half-maximal inhibitory concentration: > 40000 nM
Compound 3: a limit, no number; the forecaster's own chance of this, stated with the estimate: 65%; the middle value sits exactly at the limit.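

In this assay compound 3 gives > 40000 nM, which is a limit of the assay and not a number. Among the compounds shown here, compound 1 also stands at a limit, so no step between compound 1 and compound 3 can be read. Whether 4-methoxyphenyl in place of 3-methoxyphenyl changes the read-out at all stays open, with both compounds at the same edge: the limit of > 40000 nM in this assay, at which 2 of the 3 values shown sit.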